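A few compounds are considered here, and "the series" means these few. Any claim that something is new, unique, unknown or untested is made for them only; others in the source may bear on it.

Measured in a functional assay on the whole organism with Mus musculus as the target, in the rotarod test; a lower number here means that less compound is needed, a higher number that more compound is needed for the effect:
- compound 1 `CCCCCC(=O)NCC(=O)N(C)c1ccc(Cl)cc1C(=O)c1ccccc1Cl`: 90 mg/kg
- compound 2 `CN(C(=O)CNC(=O)c1ccccc1)c1ccc(Cl)cc1C(=O)c1ccccc1Cl`: > 100 mg/kg

In this assay compound 2 stands at > 100 mg/kg, which is a limit and not a number. This is the position described by the limit of > 100 mg/kg in this assay, at which 1 of the 2 values shown sits.

The next compound is compound 3 `CC(C)C(=O)NCC(=O)N(C)c1ccc(Cl)cc1C(=O)c1ccccc1Cl`, with the change isopropyl in place of phenyl on a carbonyl carbon. Among the measured compounds shown here, one measured step bears on this place, the exchange of pentyl for phenyl on that same carbonyl carbon: an at least 1.1-fold higher number from compound 1 to compound 2 (0.04 log units; that floor lies within the scatter). For the measured compounds named here, with only this step as a guide, no change beyond the scatter is expected, in either direction. The estimated step is a number no higher from compound 2 to compound 3 (the limit leaves the size open). The closest reference is compound 1, which carries pentyl there and gives 90 mg/kg. For compound 3 the expected value is 100 mg/kg, with an estimated range of 45 mg/kg to 220 mg/kg.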

Compound 3, dose for half-maximal effect: > 100 mg/kg
Compound 3 gave a limit, no number (the forecaster's own chance of this, stated with the estimate: 50%); the middle value sits exactly at the limit.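

In this assay the result for compound 3 is a limit and not a number, and it shows that a group with no ring on this carbonyl carbon ends up at the same limit as phenyl: the limit of > 100 mg/kg in this assay, at which 2 of the 3 values shown sit. The reading against the pentyl compound is an at least 1.1-fold higher number from compound 1 to compound 3 (0.04 log units; that floor lies within the scatter), so isopropyl and pentyl are not told apart here, any more than phenyl and pentyl were. The step between phenyl and isopropyl cannot be read, as both ends are limits.

On these data alone, how far compound 2 and compound 3 lie past the limit stays open. As far as these compounds go, compound 1 gives 90 mg/kg, and whether a longer chain such as octyl, or a chain carrying an amine or a carboxylic acid, on this carbonyl carbon moves the number beyond the scatter is also open.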